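From compound 1 to compound 3: a phenethyl addition

The source may hold more compounds than are shown below. What is called first, only, known or untested is meant among the compounds shown, and "the series" means these compounds.

Measured in a functional assay on MCF7 cells (Homo sapiens) for inhibition, read by colorimetric assay and MTT assay, with a stated time of 72 h; a lower number here means a stronger inhibitor, a higher number a weaker inhibitor:
Compound 1 `COc1ccccc1-c1cnc(OC)n1C`: > 100000 nM (a limit of the assay)
Compound 2 `C=CCCCCOc1ccccc1-c1cnc(OC)n1C`: 98000 nM

In this assay compound 1 stands at > 100000 nM, which is a limit and not a number. Compound 3 `COc1ccccc1-c1cnc(OCCCc2ccccc2)n1C` differs from compound 1 by phenethyl in place of hydrogen on a saturated chain carbon bound to an oxygen on an aromatic ring. Among the compounds with values here, one measured step bears on this, pent-4-en-1-yl in place of hydrogen on the same kind of carbon, and compound 2 gives 98000 nM. That step is an at least 1.0-fold lower number from compound 1 to compound 2 (0.00 log units; that floor lies within the scatter). On the evidence of this step alone, only a small move towards a lower number is expected, with no firm shift beyond the scatter. The expected step is an at least 1.2-fold lower number from compound 1 to compound 3 (0.09 log units; that floor lies within the scatter). For compound 3 the estimated value is 80000 nM, with an expected range of 30000 nM to 200000 nM.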

Compound 3, half-maximal inhibitory concentration: 3000 nM
Estimate against measurement, compound 3: 27-fold (1.43 log units) above, outside the stated range (below it).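

In this assay the step of an at least 33-fold lower number from compound 1 to compound 3 (1.52 log units; beyond the scatter) shows that the saturated chain carbon bound to an oxygen on an aromatic ring can carry a change that moves the number well beyond the scatter. Compound 2, with pent-4-en-1-yl on the same kind of carbon, gives 98000 nM while compound 3, with phenethyl, gives 3000 nM in the same assay, so the outcome at this place depends on which group enters. Compound 1 gives > 100000 nM as a limit and not a number, which makes the step a floor: the limit of > 100000 nM in this assay, at which 1 of the 3 values shown sits.

The compounds shown leave open how far the number would move with a longer chain carrying the same phenyl ring. They also do not tell whether an amine or a carboxylic acid at the end of the chain would be tolerated here.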